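The source may report more compounds than this note shows. Statements on the series, on what has been measured and on what is new or still open speak of the compounds shown alone.

Series so far in a functional assay on CWR22R cells (Homo sapiens) for antiproliferative activity, read by propidium iodide staining, with a stated time of 96 h; a higher number here means a weaker inhibitor, a lower number a stronger inhibitor
Compound 1 `CC(O)(COc1cccc(S(F)(F)(F)(F)F)c1)C(=O)Nc1ccc(S(F)(F)(F)(F)F)cc1` gives 17600 nM
Compound 2 `CC(O)(COc1cccc(C(F)(F)F)c1)C(=O)Nc1ccc(S(F)(F)(F)(F)F)cc1` gives 14600 nM

Among the measured compounds shown here, only one step is measured so far (a 1.2-fold lower number from compound 1 to compound 2 (0.08 log units; within the scatter)). On these two numbers compound 2 holds no separate place in the series. Compound 3 `CC(O)(COc1ccccc1C(F)(F)F)C(=O)Nc1ccc(S(F)(F)(F)(F)F)cc1` differs from compound 2 by a shift of the same group (2-(trifluoromethyl)phenyl in place of 3-(trifluoromethyl)phenyl on an oxygen on a saturated carbon), with 2-(trifluoromethyl)phenyl in place of 3-(trifluoromethyl)phenyl on an oxygen on a saturated carbon. For the measured compounds named here, no measured step shifts this group, so the one step available bears only weakly, and no change beyond the scatter is expected in this assay here. The estimated step is a 1.0-fold higher number from compound 2 to compound 3 (0.01 log units; within the scatter) and nothing larger is expected. The estimate for compound 3 is 15000 nM with an expected range from 6500 nM to 32000 nM in this series.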

Compound 3, half-maximal inhibitory concentration: 1400 nM
For compound 3 the middle estimate is 11-fold (1.03 log units) above the measured one; measured number outside the range, below it.
By their numbers in this assay, from the lowest: compound 3; then compounds 2 and 1 (each within the scatter of the next).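

In this assay, among the compounds shown here, the attachment of the trifluoromethyl group on the ring matters: with the same atoms, 2-(trifluoromethyl)phenyl in place of 3-(trifluoromethyl)phenyl on an oxygen on a saturated carbon gives a 10-fold lower number from compound 2 to compound 3 (1.02 log units; beyond the scatter) and is the first step beyond the scatter. The earlier exchange of groups, a 1.2-fold lower number from compound 1 to compound 2 (0.08 log units; within the scatter) by contrast, showed no such dependence. Nothing on hand gives a reason for this shift.

As far as these compounds go, it remains open whether a nitrile or a chlorine placed as the trifluoromethyl is in 2-(trifluoromethyl)phenyl would keep this lower number.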